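The source may hold more compounds than are shown below. What is called first, only, known or untested is meant among the compounds shown, and "the series" means these compounds.

Compounds measured in an assay on isolated protein for inhibition of histamine H2 receptor (Cavia porcellus); on this read-out lower numbers stand for tighter binding and higher numbers for weaker binding:
compound 1 `COc1ccc(N/C(S)=N/CCCOc2cccc(CN3CCCCC3)c2)cc1`, 4370 nM;
compound 2 `O=C(NCCCOc1cccc(CN2CCCCC2)c1)Nc1ccccc1`, 126 nM;
compound 3 `Cc1ccc(NC(=O)NCCCOc2cccc(CN3CCCCC3)c2)cc1`, 631 nM.

Compound 3 holds the second highest of the three numbers in this assay. Its nearest neighbour is compound 2, with a 5.0-fold higher number from compound 2 to compound 3 (0.70 log units; beyond the scatter); compound 1, which also carries a thiourea in place of the urea, shows a higher number than compound 3. Compound 4 `COc1ccc(OC)c(NC(=O)NCCCOc2cccc(CN3CCCCC3)c2)c1` differs from compound 3 by 2,5-dimethoxyphenyl in place of 4-methylphenyl on an amide-type nitrogen. Within the data shown here, the only step that bears on such a change of the aryl group is a 5.0-fold higher number from compound 2 to compound 3 (0.70 log units; beyond the scatter), a modest one. Compound 4 is therefore expected to stay near compound 3, with a 1.1-fold higher number from compound 3 to compound 4 (0.05 log units; within the scatter), likely within the scatter. Compound 4 is estimated at 700 nM, in the range 200 nM to 2500 nM.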

Compound 4, dissociation constant: 158 nM
The estimate for compound 4 lay 4.4-fold (0.65 log units) above the measured number; measured number outside the range, below it.
By their numbers in this assay, from the lowest: compounds 2 and 4 (each within the scatter of the next); then compound 3; then compound 1.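

On the amide-type nitrogen, 2,5-dimethoxyphenyl in place of 4-methylphenyl gives a 4.0-fold lower number from compound 3 to compound 4 (0.60 log units; beyond the scatter) and shows that a substituted aryl group here need not carry the higher number seen for compound 3. Against phenyl, the same group gives a 1.3-fold higher number from compound 2 to compound 4 (0.10 log units; within the scatter) and so stays within the scatter of the unsubstituted ring. Nothing available accounts for this difference between the substituted aryl groups.

Left open is which of the two methoxy groups matters, or whether both do. Also open, as far as these compounds go, is how a single methoxy group, an amine or a carboxylic acid on this ring would compare.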